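Adding a tert-butyl group to compound 2

The source may report more compounds than this note shows. Statements on the series, on what has been measured and on what is new or still open speak of the compounds shown alone.

- Compound 1 `Cc1ccc(/C(COc2ccc(Br)cc2)=N\NC(N)=S)cc1` gives 13200 nM
- Compound 2 `NC(=S)N/N=C(\COc1ccccc1)c1ccc(Br)cc1` gives 54900 nM

In an ADME assay on L929 cells (Mus musculus) for cytotoxicity, read by resazurin assay, with a stated time of 96 h (on this read-out higher numbers stand for lower toxicity in this test and lower numbers for higher toxicity in this test), compound 2 gives 54900 nM, the higher of the two numbers and beyond the usual scatter from compound 1. Compound 3 `CC(C)(C)c1ccc(OC/C(=N\NC(N)=S)c2ccc(Br)cc2)cc1` has tert-butyl in place of hydrogen on an aromatic carbon of compound 2: tert-butyl in place of hydrogen on an aromatic carbon. Within the data shown here, no measured pair shows this change alone, so the expectation is loose. Among the measured compounds shown here, it leans on the only lower number, from compound 1 at 13200 nM. A fall beyond the scatter in this assay is expected, and the estimated step is a 2.7-fold lower number from compound 2 to compound 3 (0.44 log units; beyond the scatter). For compound 3 the estimate is 20000 nM, with an expected range of 6000 nM to 55000 nM.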

Compound 3, half-maximal cytotoxic concentration: 23800 nM
Compound 3: the middle estimate sits 1.2-fold (0.08 log units) below what was measured, within the range that was stated.
By their numbers in this assay, from the lowest: compounds 1 and 3 (each within the scatter of the next); then compound 2.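

In this assay, tert-butyl in place of hydrogen on an aromatic carbon, para to a large group, gives a 2.3-fold lower number from compound 2 to compound 3 (0.36 log units; beyond the scatter), a modest step that still lies beyond the usual scatter. Among these compounds, this pair is the first to show this change alone, so it gives a direct reading for this position: here, tert-butyl goes with higher toxicity in this test. Nothing available explains the step. On these data alone, it remains open whether a methoxy group, an amine or a carboxylic acid on the same carbon would move the number in the same direction.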